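Ethyl in Place of Phenyl on a Ring Nitrogen

The compounds below may be only part of what the source reports. "The series", "measured", "known", "first", "only" and "open" are said of these compounds alone.

Of the compounds shown here, two with a shared core have been measured so far: compound 1 `CCn1c(SCC(=O)Nc2ccc(/C(C)=N/O)cc2)nnc1-c1ccc(OC)c(OC)c1` and compound 2 `COc1ccc(-c2nnc(SCC(=O)Nc3ccc(/C(C)=N/O)cc3)n2-c2ccccc2)cc1`. In a functional assay on the whole organism (strain albino) for inhibition, with Rattus norvegicus as the target, read by paw edema, with stated times of 30 min and 3 h, at a dose of 0.28 mmol/kg by the oral route (on this read-out higher numbers stand for more inhibition at the one dose given (going by the name of the read-out) and lower numbers for less inhibition), compound 1 gives 66%. In this assay compound 2 gives 57%, the lower of the two numbers, although the gap to compound 1 lies within the usual scatter of this measurement, so the two cannot be told apart on these data. For the measured compounds named here, the two compounds differ from each other in more than one place, so no single step between them can be read.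

Compound 3 `CCn1c(SCC(=O)Nc2ccc(/C(C)=N/O)cc2)nnc1-c1ccc(OC)cc1` has not yet been measured. It differs from compound 2 in one place: ethyl in place of phenyl on an aromatic nitrogen. Compound 1 already carries the same ethyl group on its ring nitrogen and gives 66%, a number within the scatter of compound 2. On that basis the step from compound 2 to compound 3 is expected to be small, a number 5 percentage points higher from compound 2 to compound 3 (within the scatter), with no direction that stands out beyond the scatter. For compound 3 in this assay the estimate is 62%, with a likely range from 48% to 76%.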

Compound 3, a percentage reported as inhibition, in the whole organism at one dose (the size of the read-out at that dose, not a potency): 60%
Compound 3: middle estimate off by 2 percentage points, on the high side, within the range that was stated.
By their numbers in this assay, from the lowest: compounds 2, 3 and 1 (each within the scatter of the next).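

In this assay, for the compounds shown here, the change from phenyl to ethyl on the aromatic nitrogen gives a number 3 percentage points higher from compound 2 to compound 3 (within the scatter) and is the first single change that can be read at this position: an aromatic ring of carbon gives way to a small open chain, and the inhibition at this one dose cannot be told apart from what it was. The second step, hydrogen in place of methoxy on an aromatic carbon, gives a number 6 percentage points lower from compound 1 to compound 3 (within the scatter) and so also stays too small to separate the two compounds, which means that this methoxy makes no readable difference while ethyl sits on the ring nitrogen. Nothing among the available data offers an explanation for either result.

Each of these steps rests on a single pair of compounds at a single dose, so a real but small difference could still lie hidden in the scatter, and the numbers say nothing about potency. As far as these compounds go, it remains open whether a longer chain such as butyl, a benzyl group or a chain ending in an amine or a carboxylic acid on that ring nitrogen would keep the inhibition in the same range.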